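Methoxy Replaces Methyl on the Benzyl Group

The source may report more compounds than this note shows. Statements on the series, on what has been measured and on what is new or still open speak of the compounds shown alone.

Of the compounds shown here, three sharing one core have been measured in a functional assay on spleen for antagonist activity at Alpha-1B adrenergic receptor (Rattus norvegicus); on this read-out lower numbers stand for lower potency and higher numbers for higher potency (the scale is a negative logarithm). Compound 1 `COc1cccc(OC)c1OCCNCCOc1ccccc1OCc1ccccc1` carries an unsubstituted benzyl group and gives 8.3. Compound 2 `COc1cccc(OC)c1OCCNCCOc1ccccc1OCc1ccccc1C` bears a 2-methylphenyl on the saturated chain carbon and gives 7.67, a drop recorded as a number 0.63 log units lower from compound 1 to compound 2 (beyond the scatter). Compound 3 `COc1cccc(OC)c1OCCNCCOc1ccccc1OCc1cccc(C)c1` bears a 3-methylphenyl there and gives 8.2; the step of a number 0.10 log units lower from compound 1 to compound 3 (within the scatter) is within the scatter, while the step of a number 0.53 log units higher from compound 2 to compound 3 (beyond the scatter) is a modest gain. Compound 3 therefore stands second of the three numbers, close to compound 1 and clearly above compound 2.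

Compound 4 `COc1ccccc1COc1ccccc1OCCNCCOc1c(OC)cccc1OC` is not yet measured. It differs from compound 3 by 2-methoxyphenyl in place of 3-methylphenyl on a saturated chain carbon bound to an oxygen on an aromatic ring. Within the data shown here, no measured step swaps a methyl for a methoxy, but the pair of compounds 2 and 3 shows that moving a substituent from the 2-methylphenyl to the 3-methylphenyl arrangement raised the number by a modest amount, and the step from compound 1 to compound 2 shows that a 2-methylphenyl sat below the bare benzyl. A modest loss is therefore expected in this assay for compound 4, estimated as a number 0.40 log units lower from compound 3 to compound 4 (beyond the scatter). Compound 4 is expected to give 7.8, with a range from 7.3 to 8.3.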

Compound 4, negative logarithm of the antagonist equilibrium constant: 8.13
Estimate against measurement, compound 4: 0.33 log units below; low and high end bracket the measured number.
By their numbers in this assay, from the lowest: compound 2; then compounds 4, 3 and 1 (each within the scatter of the next).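

In this assay the change at this position, on a saturated chain carbon bound to an oxygen on an aromatic ring, gives a number 0.07 log units lower from compound 3 to compound 4 (within the scatter) and the comparison with the unsubstituted benzyl gives a number 0.17 log units lower from compound 1 to compound 4 (within the scatter) so a 2-methoxyphenyl here stands level with both the 3-methylphenyl and the bare ring. The closest comparison is with the 2-methylphenyl, where methoxy in place of methyl gives a number 0.46 log units higher from compound 2 to compound 4 (beyond the scatter) and this shows that the lower number of compound 2 does not carry over to every group written at the 2 position of this ring: it goes with the methyl, not with the place alone, as far as these four compounds can show. Nothing measured here bears on why methyl and methoxy part in this way.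

The compounds shown leave open whether the methyl result in compound 2 or the methoxy result in compound 4 is the more usual one at this place, which a 2-chlorophenyl, a 2-ethoxyphenyl or a 2-hydroxyphenyl would help to settle. They also leave open how a 3-methoxyphenyl would compare with the 3-methylphenyl of compound 3 in this assay and whether an amine on this ring would be accepted as well.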